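Compound 1 to compound 4: adding 4-fluorophenyl

The source may hold more compounds than are shown below. What is called first, only, known or untested is meant among the compounds shown, and "the series" means these compounds.

For the measured compounds named here, in a physicochemical assay for solubility, read by HPLC, in phosphate buffer, measured as kinetic solubility, at pH 7.4 (a lower number here means a less soluble compound, a higher number a more soluble compound), compound 1 (`CCC(=O)c1ccn(-c2ccc(S(N)(=O)=O)cc2)c1C`) gives 100000 nM as the highest of three numbers so far. Compound 3 (`CCOC(=O)c1cc(-c2ccc(Cl)cc2)n(-c2ccc3cc[nH]c3c2)c1C`) reads 5100 nM and compound 2 (`CCC(=O)c1cc(-c2ccc(Cl)cc2)n(-c2ccc(S(=O)(=O)N(C)C)cc2)c1C`) reads 1200 nM on the same scale, both beyond the scatter from compound 1. Going by the values given here, each of these two carries an aryl group where compound 1 has hydrogen, but each also differs from compound 1 elsewhere, so no single-change step between measured compounds is available.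

Compound 4 (`CCC(=O)c1cc(-c2ccc(F)cc2)n(-c2ccc(S(N)(=O)=O)cc2)c1C`) has not yet been measured. Its change from compound 1 is 4-fluorophenyl in place of hydrogen on an aromatic carbon and amounts to 4-fluorophenyl in place of hydrogen on an aromatic carbon, next to the ring nitrogen. Among the compounds with values here, with compound 3 at 5100 nM and compound 2 at 1200 nM as the only guides, a lower number in this assay is expected. The estimated step is a 25-fold lower number from compound 1 to compound 4 (1.40 log units; beyond the scatter) in that direction, well beyond the scatter. For compound 4 the expected value is 4000 nM within an estimated range of 1000 nM to 16000 nM for now.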

Compound 4, solubility: 29300 nM
Compound 4: the middle estimate sits 7.3-fold (0.86 log units) below what was measured; measured number outside the range, above it.
By their numbers in this assay, from the lowest: compound 2; then compound 3; then compound 4; then compound 1.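

In this assay, 4-fluorophenyl in place of hydrogen on an aromatic carbon, next to the ring nitrogen, can now be read as a single change, giving a 3.4-fold lower number from compound 1 to compound 4 (0.53 log units; beyond the scatter), a modest step. The entering group brings 7 heavy atoms and one six-membered aromatic ring of carbon only, yet compound 4 still reads 29300 nM. No measurement shown here explains the size of this step.

With a single group shown at this position, the contribution of the phenyl ring cannot be separated from that of its fluorine. Plain phenyl would isolate the fluorine, while a methyl group or a phenyl ring bearing a carboxylic acid or an amine would show how the step varies with the group placed here.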